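Swapping 2,5-dimethylphenyl for 3-chlorophenyl on the sulfonamide

The source may report more compounds than this note shows. Statements on the series, on what has been measured and on what is new or still open speak of the compounds shown alone.

In a functional assay on CHO-TAX 5-6 cells (Cricetulus griseus) for antiproliferative activity, read by sulforhodamine B assay, with a stated time of 48 h (a higher number here means a weaker inhibitor, a lower number a stronger inhibitor), compound 1 (`Cc1cc(C)cc(NS(=O)(=O)c2ccc(N3CCNC3=O)cc2)c1`) gives 120 nM and compound 2 (`Cc1ccc(C)c(NS(=O)(=O)c2ccc(N3CCNC3=O)cc2)c1`) gives 54 nM, the lower of the two numbers. Within the data shown here, the only measured step is a 2.2-fold lower number from compound 1 to compound 2 (0.35 log units; beyond the scatter). It is modest in size and comes with 2,5-dimethylphenyl in place of 3,5-dimethylphenyl on a sulfonamide nitrogen. Compound 3 (`O=C1NCCN1c1ccc(S(=O)(=O)Nc2cccc(Cl)c2)cc1`) has 3-chlorophenyl in place of 2,5-dimethylphenyl at that same sulfonamide nitrogen: 3-chlorophenyl in place of 2,5-dimethylphenyl on a sulfonamide nitrogen. Among the measured compounds shown here, no measured compound carries chlorine, so that single step guides the size of the change only loosely. Compound 2 also holds the lower number, which leaves a modest rise as the likelier outcome in this assay. The expected change is a 2.0-fold higher number from compound 2 to compound 3 (0.31 log units; beyond the scatter). For compound 3 the estimated value is 110 nM, with an expected range of 35 nM to 350 nM.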

Compound 3, half-maximal inhibitory concentration: 58 nM
Compound 3: the middle estimate sits 1.9-fold (0.28 log units) above what was measured; the range from low to high includes it.
By their numbers in this assay, from the lowest: compounds 2 and 3 (each within the scatter of the next); then compound 1.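

In this assay, the step of a 1.1-fold higher number from compound 2 to compound 3 (0.03 log units; within the scatter) shows that 3-chlorophenyl can stand in for 2,5-dimethylphenyl on the sulfonamide nitrogen with no difference that can be told from the scatter, so this position now holds a chlorine-bearing group as well as methyl-bearing ones. The other new step, a 2.1-fold lower number from compound 1 to compound 3 (0.32 log units; beyond the scatter), is modest but beyond the scatter, and 3,5-dimethylphenyl now stands apart from two different groups at this nitrogen rather than from one. Nothing available explains why these groups give the numbers they do.

Still open, as far as these compounds go, is how a phenyl group carrying a methoxy group, an amine or a carboxylic acid would read at this nitrogen. The compounds shown also leave open what a longer chain in place of the phenyl group would do.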